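The source may hold more compounds than are shown below. What is called first, only, known or untested is meant among the compounds shown, and "the series" means these compounds.

Of the compounds shown here, three sharing one core have been measured in an assay on isolated protein for binding affinity to leukotriene B4 receptor 1 (Homo sapiens), tested at 1 uM; on this read-out lower numbers stand for less inhibition and higher numbers for more inhibition at the one concentration tested (going by the name of the read-out). Compound 1 `CCc1cc(C(C)=O)c(O)cc1OCCCCC#N` gives 57% in this assay, compound 2 `CCc1cc(C(C)=O)c(O)cc1OCCCC(C)(C)c1nnn[nH]1` gives 76%, and compound 3 `CCc1cc(C(C)=O)c(O)cc1OCCCCCC(C)(C)c1nnnn1C` gives 59%. On these numbers compound 3 stands second highest of the three: compound 1 lies within the scatter of it, while compound 2 lies beyond the scatter above it. Going by the values given here, the only step between compounds that differ in a single place is a number 19 percentage points higher from compound 1 to compound 2 (beyond the scatter).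

Compound 4 `CCc1cc(C(C)=O)c(O)cc1OCCCCCn1cncn1` has not yet been measured. It differs from compound 3 by 1H-1,2,4-triazol-1-yl in place of 1-methyl-1-(1-methyl-1H-tetrazol-5-yl)ethyl on a saturated chain carbon, five bonds along the chain from an oxygen on an aromatic ring. The step from compound 1 to compound 2 bears only loosely on this change, since there a tetrazole ring was added where a nitrile had been, whereas here one five-membered aromatic ring replaces another and the two methyl groups on the chain carbon are lost. Compound 3 and compound 1 lie within the scatter of each other, so the difference between their chain ends did not shift this assay beyond the scatter. A step of a number 7 percentage points lower from compound 3 to compound 4 (within the scatter) is therefore expected, within the scatter or at most slightly downward. Compound 4 is estimated to give 52% in this assay, with a range from 32% to 70%.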

Compound 4, a percentage reported as inhibition, at one concentration (the size of the read-out at that concentration, not a potency): 30%
Estimate against measurement, compound 4: 22 percentage points above; measured number outside the range, below it.
By their numbers in this assay, from the lowest: compound 4; then compounds 1 and 3 (each within the scatter of the next); then compound 2.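

In this assay, the end of the chain proves to matter at this position: placing 1H-1,2,4-triazol-1-yl where 1-methyl-1-(1-methyl-1H-tetrazol-5-yl)ethyl stood, on a saturated chain carbon, five bonds along the chain from an oxygen on an aromatic ring, gives a number 29 percentage points lower from compound 3 to compound 4 (beyond the scatter), so exchanging one five-membered aromatic ring for another is not a neutral change here. Going by these compounds alone, compound 4 also falls clear of the other two, with a number 27 percentage points lower from compound 1 to compound 4 (beyond the scatter) and a number 46 percentage points lower from compound 2 to compound 4 (beyond the scatter), which makes it the lowest of the series, whereas the only step between the earlier compounds ran upward. Nothing available accounts for this drop.

The single change in compound 4 swaps the ring and removes the methyl groups on the chain carbon together, so the compounds shown cannot separate the two, and a 1H-1,2,4-triazol-1-yl group carrying those methyl groups would be needed to do so. From the compounds shown here alone, how a carboxylic acid or an amine at the end of the chain would read in this assay also remains open.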